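The compounds below may be only part of what the source reports. "The series", "measured", "known", "first", "only" and "open" are said of these compounds alone.

Compound 1 `CN(C)c1ccc2c(=O)c(C(=O)Nc3cc(F)cc(F)c3)cn(-c3ccc(OCCCCCCC[N+]45CCN(CC4)CC5)cc3Cl)c2n1` and compound 2 `CN(C)c1ccc2c(=O)c(C(=O)Nc3cc(F)cc(F)c3)cn(-c3ccc(OCCCCCCC[N+]45CCN(CC4)CC5)cc3F)c2n1` share one core and differ in a single spot: fluoro in place of chloro on an aromatic carbon. In an assay on LX2 cells for inhibition of COL1A1 promoter (Homo sapiens), read by a luciferase reporter, with a stated time of 24 h, tested at 20 uM (a lower number here means a weaker effect, a higher number a stronger effect of the compound at the concentration tested), compound 1 gives 40.1%, whereas compound 2 gives 9.02%, and the step between them is a number 31.1 percentage points lower from compound 1 to compound 2 (beyond the scatter). Compound 3 `CN1CC[N+](C)(CCCCCCCOc2ccc(-n3cc(C(=O)Nc4cc(F)cc(F)c4)c(=O)c4ccc(N(C)C)nc43)c(Cl)c2)CC1` carries a different core. The difference from compound 1 is a group of 8 heavy atoms (6 carbon, 2 nitrogen; one six-membered non-aromatic ring with 2 hetero atoms) in place of a group of 8 heavy atoms (6 carbon, 2 nitrogen; 2 six-membered non-aromatic rings with 2 hetero atoms each), on a saturated chain carbon, seven bonds along the chain from an oxygen on an aromatic ring. In this assay compound 3 shows "not active" (no number reported). Compound 4 `CN1CC[N+](C)(CCCCCCCOc2ccc(-n3cc(C(=O)Nc4cc(F)cc(F)c4)c(=O)c4ccc(N(C)C)nc43)c(F)c2)CC1` arises from compound 3 through the same change, (fluoro in place of chloro on an aromatic carbon). That change already left compound 2 with a weak effect, and compound 3 starts without any reported number, so there is little room for a further drop; the step to compound 4 is expected to be small, or to end again with no number at all. Compound 4 is expected to give 3%, between -10% and 15%, because the same change produced a number 31.1 percentage points lower from compound 1 to compound 2 (beyond the scatter).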

Compound 4, a percentage reported as inhibition, at one concentration (the size of the read-out at that concentration, not a potency): "not active" (no number reported)
Compound 4: no number reported; there is nothing to compare the estimate with.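

In this assay, within the data shown here, neither compound 3 nor compound 4 carries a number, and no step between them can be read. Nothing measured here offers an explanation. From the compounds shown here alone, whether fluoro in place of chloro changes the effect with this core stays open.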